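The compounds below may be only part of what the source reports. "The series", "measured", "known", "first", "only" and "open" are said of these compounds alone.

Compound 3 `COc1ccccc1-c1cn2ccnc2c(-c2ccc3ncn(C4CCCCC4)c3c2)n1` is the highest of the three measured numbers in a functional assay on EKVX cells (Homo sapiens) for inhibition, read by sulforhodamine B assay, with a stated time of 48 h, tested at 10 uM (on this read-out lower numbers stand for less inhibition and higher numbers for more inhibition at the one concentration tested (going by the name of the read-out)), where compound 3 gives 13.4%, though both neighbours lie within the scatter of it: compound 2 `Clc1ccc(-c2cn3ccnc3c(-c3ccc4ncn(C5CCCCC5)c4c3)n2)cc1` gives 13.1% and compound 1 `Fc1ccc(-c2cn3ccnc3c(-c3ccc4ncn(C5CCCCC5)c4c3)n2)cc1` gives 10.5%. The steps of a number 2.6 percentage points higher from compound 1 to compound 2 (within the scatter), a number 2.9 percentage points higher from compound 1 to compound 3 (within the scatter) and a number 0.3 percentage points higher from compound 2 to compound 3 (within the scatter) are all within the scatter. Compound 4 `Fc1ccccc1-c1cn2ccnc2c(-c2ccc3ncn(C4CCCCC4)c3c2)n1` differs from compound 3 in one place: fluoro in place of methoxy on an aromatic carbon. For the measured compounds named here, only the two steps that bring in the 2-methoxyphenyl bear on this change, and both were within the scatter; no measured step removes a methoxy for a fluoro. Compound 4 is therefore expected to show a step of a number 1.9 percentage points lower from compound 3 to compound 4 (within the scatter), not beyond the scatter. Compound 4 is estimated at 11.5%, between 4% and 19%.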

Compound 4, a percentage reported as inhibition, at one concentration (the size of the read-out at that concentration, not a potency): 16%
Compound 4: middle estimate off by 4.5 percentage points, on the low side; measured number inside the range.
By their numbers in this assay, from the lowest: compounds 1, 2, 3 and 4 (each within the scatter of the next).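

In this assay, for the compounds shown here, fluoro in place of methoxy on this aromatic carbon, ortho to a large group, gives a number 2.6 percentage points higher from compound 3 to compound 4 (within the scatter) as the first measured change that starts from the 2-methoxyphenyl group. Set against the 4-substituted phenyl compounds, the 2-fluorophenyl group gives a number 2.9 percentage points higher from compound 2 to compound 4 (within the scatter) and a number 5.5 percentage points higher from compound 1 to compound 4 (within the scatter), so all four compounds remain within the scatter of one another. No supporting data bear on this result. As far as these compounds go, whether an amine or a carboxylic acid on this carbon would move the number beyond the scatter remains open.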